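Swapping a Phenyl for a Pyridyl on the Glucagon Core

The compounds below may be only part of what the source reports. "The series", "measured", "known", "first", "only" and "open" are said of these compounds alone.

Of the compounds shown here, three that share one core have been tested in a functional assay on CHO cells for antagonist activity at Glucagon receptor (Homo sapiens), read by cAMP accumulation, with stated times of 30 min and 45 min; on this read-out lower numbers stand for stronger inhibition and higher numbers for weaker inhibition. Compound 1 `CC(C)(C)CC[C@H](c1ccc(C(=O)NCc2nn[nH]n2)cc1)N1C(=O)C(c2cncc(Cl)c2)=N[C@]12CC[C@@H](C(C)(C)C)CC2` gives 480 nM. Compound 2 `C[C@H](c1ccc(C(=O)NCCC(=O)O)cc1)N1C(=O)C(c2cccc(OC(F)(F)F)c2)=N[C@]12CC[C@@H](C(C)(C)C)CC2` gives 840 nM. Compound 3 `CC(C)(C)CC[C@H](c1ccc(C(=O)NCc2nn[nH]n2)cc1)N1C(=O)C(c2cccc(C(F)(F)F)c2)=N[C@]12CC[C@@H](C(C)(C)C)CC2` gives 180 nM, the lowest of the three numbers; its gaps to compound 1 and to compound 2 are both beyond the scatter, so compound 3 is the strongest inhibitor of the set.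

Compound 4 `CC(C)(C)CC[C@H](c1ccc(C(=O)NCc2nn[nH]n2)cc1)N1C(=O)C(c2cnccc2C(F)(F)F)=N[C@]12CC[C@@H](C(C)(C)C)CC2` differs from compound 3 in one place: 4-(trifluoromethyl)pyridin-3-yl in place of 3-(trifluoromethyl)phenyl on a carbon with a double bond to nitrogen. For the measured compounds named here, only one measured step touches this place, a 2.7-fold lower number from compound 1 to compound 3 (0.43 log units; beyond the scatter), where a ring of carbon only replaced a ring with one hetero atom and the number fell. The change now in view goes the other way, back to a ring with one hetero atom, while the trifluoromethyl group is kept. That earlier step also exchanged a chloro for a trifluoromethyl, so its full size may not carry over, but it points to a modest rise in the number, beyond the scatter. Compound 4 is therefore expected to give 350 nM, with a range from 150 nM to 900 nM. This corresponds to an expected step of a 1.9-fold higher number from compound 3 to compound 4 (0.29 log units; within the scatter).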

Compound 4, half-maximal inhibitory concentration: 1200 nM
For compound 4 the middle estimate is 3.4-fold (0.54 log units) below the measured one; the whole stated range lies below it.
By their numbers in this assay, from the lowest: compound 3; then compounds 1, 2 and 4 (each within the scatter of the next, the first and the last beyond it).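

In this assay, the step from a ring of carbon only to a ring with one hetero atom, with the trifluoromethyl group kept, gives a 6.7-fold higher number from compound 3 to compound 4 (0.82 log units; beyond the scatter), so this position responds clearly to this change even when the group on the ring stays the same. The two names show that this step alters more than the ring. The trifluoromethyl group goes from the 3 of 3-(trifluoromethyl)phenyl to the 4 of 4-(trifluoromethyl)pyridin-3-yl, and a 2.5-fold higher number from compound 1 to compound 4 (0.40 log units; beyond the scatter) shows that two rings with one hetero atom can also differ beyond the scatter, so the ring type alone does not set the number here. No measurement is available that explains these differences.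

The compounds shown leave open how much of the rise belongs to the ring nitrogen and how much to the new place of the trifluoromethyl group, a question that a 5-(trifluoromethyl)pyridin-3-yl group at this position could help separate. A 3-chlorophenyl group could likewise show how a chloro substituent behaves on a ring of carbon only.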